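The source may report more compounds than this note shows. Statements on the series, on what has been measured and on what is new or still open speak of the compounds shown alone.

In an assay on isolated protein for inhibition of vascular endothelial growth factor receptor 1 (Homo sapiens), read by HTRF, tested at 10 uM (a lower number here means less inhibition, a higher number more inhibition at the concentration tested (going by the name of the read-out)), compound 2 `Cc1cccc(N(C)c2cc(Nc3cccc(C(=O)N(CC(C)C)CC(C)C)c3)ncn2)c1` gives 5%. Compound 3 `COC[C@@H]1CCCN1C(=O)[C@@H]1CCCN1c1nccc(Nc2ccccc2)n1` gives 1% in this assay, and compound 1 `COC[C@@H]1CCCN1C(=O)C1CCCN1c1cc(Nc2cccc(Br)c2)ncn1` gives 0%; both gaps to compound 2 lie within the usual scatter, so on these numbers compound 2 cannot be told apart from the other two, and none of the three shows appreciable inhibition at the concentration tested. Compound 4 `Cc1cccc(N(C)c2cc(Nc3cccc(C(=O)N4CCCC5CCCCC54)c3)ncn2)c1` differs from compound 2 in one place: a group of 10 heavy atoms (9 carbon, 1 nitrogen; one six-membered non-aromatic ring of carbon only, one six-membered non-aromatic ring with 1 hetero atom) in place of a group of 9 heavy atoms (8 carbon, 1 nitrogen; no ring), on a carbonyl carbon. Among the compounds with values here, no measured pair shows the effect of such a change, and with all three measured compounds sitting near zero, no step beyond the scatter is expected in this assay on going to compound 4. Compound 4 is therefore expected to give about 3%, with a likely range from 0% to 15%. The expected step is a number 2 percentage points lower from compound 2 to compound 4 (within the scatter).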

Compound 4, a percentage reported as inhibition, at one concentration (the size of the read-out at that concentration, not a potency): 8%
For compound 4 the middle estimate is 5 percentage points below the measured one; low and high end bracket the measured number.
By their numbers in this assay, from the lowest: compounds 1, 3, 2 and 4 (each within the scatter of the next).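

In this assay, the group with two six-membered non-aromatic rings in place of diisobutylamino on the carbonyl carbon gives a number 3 percentage points higher from compound 2 to compound 4 (within the scatter). This first pair at this position shows that the open-chain group can give way to this larger ring-bearing group with no change in inhibition that can be told from the scatter. No data here speak to a cause for this step. Going by these compounds, whether a group on this carbonyl carbon carrying a carboxylic acid or a primary amine would move inhibition beyond the scatter remains open.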